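Thiocyanate series: aryl exchange on the fused core

The compounds below may be only part of what the source reports. "The series", "measured", "known", "first", "only" and "open" are said of these compounds alone.

Measured so far:
compound 1, `O=Cc1c(-c2ccc(Cl)cc2Cl)nc2sc(Cc3ccc(Cl)cc3)nn12` — 79000 nM
compound 2, `N#CSc1c(-c2ccc(F)cc2)nc2sc(Cc3ccc(Cl)cc3)nn12` — 24000 nM

In an ADME assay on CCRF-CEM cells (Homo sapiens) for cytotoxicity, with a stated time of 72 h (on this read-out lower numbers stand for stronger inhibition and higher numbers for weaker inhibition), compound 2 gives 24000 nM, the lowest of the two numbers at hand; compound 1 gives 79000 nM, a higher number, and the gap between the two lies beyond the scatter. Among the compounds with values here, the two differ in two places at once, so no single step between them can be read.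

Compound 3, `N#CSc1c(-c2ccc(Cl)cc2Cl)nc2sc(Cc3ccc(Cl)cc3)nn12`, has not been measured. It is compound 2 with 2,4-dichlorophenyl in place of 4-fluorophenyl on an aromatic carbon. Within the data shown here, no measured pair isolates this change. Compound 1 carries the same 2,4-dichlorophenyl group and gives 79000 nM, a weaker result than compound 2, but it also carries an aldehyde where compound 2 has the cyanosulfanyl group, so that comparison is mixed. The expected step from compound 2 to compound 3 in this assay is therefore a 1.6-fold higher number from compound 2 to compound 3 (0.20 log units; within the scatter), a modest move towards a higher number with wide uncertainty. For compound 3 the estimate in this assay is 38000 nM, within the range 12000 nM to 120000 nM.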

Compound 3, half-maximal inhibitory concentration: 46000 nM
Estimate against measurement, compound 3: 1.2-fold (0.08 log units) below, within the range that was stated.
By their numbers in this assay, from the lowest: compounds 2, 3 and 1 (each within the scatter of the next, the first and the last beyond it).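

In this assay the aryl exchange can now be read on its own: a 1.9-fold higher number from compound 2 to compound 3 (0.28 log units; within the scatter), so 2,4-dichlorophenyl in place of 4-fluorophenyl on this aromatic carbon does not separate the two compounds beyond the scatter. The second change, cyanosulfanyl in place of formyl on an aromatic carbon, can also be read alone: a 1.7-fold lower number from compound 1 to compound 3 (0.23 log units; within the scatter), again within the scatter, so the gap between compound 1 and compound 2 spans two steps, neither of which exceeds the scatter by itself. Nothing at hand accounts for the size of either step.

On these data alone, whether an amine or a carboxylic acid in place of the cyanosulfanyl group would give a step beyond the scatter stays open. So does the effect of an unsubstituted phenyl ring on the aromatic carbon that carries the aryl group.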